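A few compounds are considered here, and "the series" means these few. Any claim that something is new, unique, unknown or untested is made for them only; others in the source may bear on it.

Measured compounds:
- compound 1, `O=C(O)CN1C(=O)/C(=C/c2nc3ccccc3n2Cc2ccc(Br)cc2F)SC1=S`: 21100 nM
- compound 2, `O=C(O)CN1C(=O)/C(=C/c2nc3ccccc3n2Cc2ccc([N+](=O)[O-])cc2)SC1=S`: 8270 nM

In a functional assay on PC-3 cells (Homo sapiens) for cytotoxicity, read by MTT assay, with a stated time of 48 h (on this read-out lower numbers stand for stronger inhibition and higher numbers for weaker inhibition), compound 1 gives 21100 nM, the highest of the two numbers seen so far. Among the compounds with values here, its only neighbour is compound 2, which gives 8270 nM in this assay, and the step of a 2.6-fold lower number from compound 1 to compound 2 (0.41 log units; beyond the scatter) arises from 4-nitrophenyl in place of 4-bromo-2-fluorophenyl on the saturated chain carbon bound to the aromatic nitrogen.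

Compound 3, `O=C(O)CN1C(=O)/C(=C/c2nc3ccccc3n2Cc2ccc(F)cc2F)SC1=S`, has not yet been measured in this assay. It differs from compound 1 by fluoro in place of bromo on an aromatic carbon, so the 4-bromo-2-fluorobenzyl of compound 1 becomes 2,4-difluorobenzyl while the rest of the shared core is untouched.

Within the data shown here, only the step from compound 1 to compound 2 bears on this change, and it replaces the whole aryl group rather than a single substituent, so it gives little direct guidance. A single halogen swap on the same ring is expected to move the number less than that, if at all. Compound 3 is therefore expected to show a 1.2-fold lower number from compound 1 to compound 3 (0.07 log units; within the scatter), which lies within the scatter. Compound 3 is estimated at 18000 nM, with a range from 7000 nM to 45000 nM.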

Compound 3, half-maximal inhibitory concentration: 21700 nM
The estimate for compound 3 lay 1.2-fold (0.08 log units) below the measured number, and the stated range covers the measured number.
By their numbers in this assay, from the lowest: compound 2; then compounds 1 and 3 (each within the scatter of the next).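

In this assay, replacing bromo with fluoro on the aromatic carbon para to a large group and meta to a fluoro group gives a 1.0-fold higher number from compound 1 to compound 3 (0.01 log units; within the scatter), so the number does not register this halogen swap at this place. The earlier compounds shown here could show only that exchanging the whole aryl group moves the number, not how a single substituent on that ring behaves. With 2,4-difluorophenyl in place of 4-nitrophenyl there is a 2.6-fold higher number from compound 2 to compound 3 (0.42 log units; beyond the scatter), which is close in size to a 2.6-fold lower number from compound 1 to compound 2 (0.41 log units; beyond the scatter), so among the three compounds shown, compound 2 stands apart from the two halogen-only rings, which read alike. Nothing at hand explains why the swap of halogens leaves the number in place or why compound 2 stands apart.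

The 4-nitrophenyl of compound 2 both carries a nitro group and lacks the second halogen of the other two rings, so the compounds shown do not separate these two differences. On these data alone, how an amine or a methoxy group would read at the place of the bromo also remains open.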